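The source may report more compounds than this note shows. Statements on the series, on what has been measured and on what is new or still open speak of the compounds shown alone.

Compounds measured in a functional assay on Gurav cells (Homo sapiens) for inhibition, read by sulforhodamine B assay; on this read-out higher numbers stand for weaker inhibition of growth and lower numbers for stronger inhibition of growth:
- Compound 1 `c1ccc(-c2ccc(-c3ccc(-c4nc5ccccc5[nH]4)cc3)cc2)cc1`: 100000 nM
- Compound 2 `COc1ccc(-c2ccc(-c3ccc(-c4nc5cc(C)ccc5[nH]4)cc3)cc2)cc1OC`: 1310 nM
- Compound 3 `Fc1ccc(-c2ccc(-c3ccc(-c4nc5ccccc5[nH]4)cc3)cc2)cc1`: 100000 nM

Compound 3 gives 100000 nM, level with compound 1, and together they hold the highest of the three numbers. Compound 2 lies much lower at 1310 nM, but it differs from compound 3 in more than one place, so no single change can be read from that gap.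

The next structure is compound 4 `FC(F)(F)Oc1ccc(-c2ccc(-c3ccc(-c4nc5ccccc5[nH]4)cc3)cc2)cc1`, with trifluoromethoxy in place of fluoro on an aromatic carbon, para to a large group: trifluoromethoxy in place of fluoro on an aromatic carbon. For the measured compounds named here, the only measured single-place step is no change at the digits printed from compound 1 to compound 3 (within the scatter), which swapped hydrogen for fluoro and stayed within the scatter. The incoming group is larger than anything that step tested, so the evidence is thin. The expectation in this assay is therefore little movement, with any real shift toward lower numbers. The expected change is a 1.7-fold lower number from compound 3 to compound 4 (0.22 log units; within the scatter). Compound 4 is estimated at 60000 nM, with an expected range of 8000 nM to 100000 nM.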

Compound 4, concentration for 50% growth inhibition: 100000 nM
The estimate for compound 4 lay 1.7-fold (0.22 log units) below the measured number, and the stated range covers the measured number.
By their numbers in this assay, from the lowest: compound 2; then compounds 1, 3 and 4 (each within the scatter of the next).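

In this assay, going from fluoro, with 1 heavy atom, to trifluoromethoxy, with 5 heavy atoms and 1 hydrogen-bond acceptor, gives no change at the digits printed from compound 3 to compound 4 (within the scatter) on this aromatic carbon. Set against plain hydrogen, the same group gives no change at the digits printed from compound 1 to compound 4 (within the scatter), so hydrogen, fluoro and trifluoromethoxy at this place all leave the number level, and a much bigger group here is no different in this assay from a single atom. Nothing measured here explains why this position gives so flat a result.

Going by these compounds, whether an amine or a carboxylic acid at this place would move the number remains open. Compound 2 differs from these compounds in more than one place, so its separate changes cannot be read from them.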